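The source may report more compounds than this note shows. Statements on the series, on what has been measured and on what is new or still open speak of the compounds shown alone.

Measured so far:
- compound 1, `CN(C(=O)NC(=O)c1c(F)cccc1F)c1nc(C(F)(F)F)c(C(=O)N/N=C/c2cccc(C(F)(F)F)c2)s1`, 25.9 ug/mL in a functional assay on BCG823 cells (Homo sapiens) for inhibition, read by MTT assay, with a stated time of 72 h; a higher number here means a weaker inhibitor, a lower number a stronger inhibitor
- compound 2, `CN(C(=O)NC(=O)c1ccc(F)c(F)c1)c1nc(C(F)(F)F)c(C(=O)N/N=C/c2ccccc2C(F)(F)F)s1`, 3.66 ug/mL in this assay
- compound 3, `CN(C(=O)NC(=O)c1ccc(C(F)(F)F)cc1)c1nc(C(F)(F)F)c(C(=O)N/N=C/c2cccc(C(F)(F)F)c2)s1`, 1.84 ug/mL in this assay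

Compound 3 gives the lowest number of the three; compound 2 lies within the scatter of it, while compound 1 is well beyond it. Going by the values given here, the one single-point step measured so far, a 14-fold lower number from compound 1 to compound 3 (1.15 log units; beyond the scatter), concerns the aryl group on the carbonyl carbon and is large. Compound 4, `CN(C(=O)NC(=O)c1ccc(F)c(F)c1)c1nc(C(F)(F)F)c(C(=O)N/N=C/c2cccc(C(F)(F)F)c2)s1`, has not yet been measured. It differs from compound 3 by 3,4-difluorophenyl in place of 4-(trifluoromethyl)phenyl on a carbonyl carbon. Among the compounds with values here, no measured step covers this exact exchange. Compound 2 carries the same 3,4-difluorophenyl group on the carbonyl carbon and differs from compound 4 only in the other aryl ring; its value and that of compound 3 fall within the scatter of each other. Given 3.66 ug/mL for compound 2 and 1.84 ug/mL for compound 3, a small step is expected, a 1.6-fold higher number from compound 3 to compound 4 (0.21 log units; within the scatter), probably not beyond the scatter. Compound 4 is estimated at 3 ug/mL, with a range from 1.2 ug/mL to 8 ug/mL.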

Compound 4, half-maximal inhibitory concentration: 4.46 ug/mL
Estimate against measurement, compound 4: 1.5-fold (0.17 log units) below; low and high end bracket the measured number.
By their numbers in this assay, from the lowest: compounds 3, 2 and 4 (each within the scatter of the next, the first and the last beyond it); then compound 1.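

In this assay, with 3-(trifluoromethyl)phenyl held constant on the carbon with a double bond to nitrogen, the position on the carbonyl carbon also separates two well-performing aryl groups: a 2.4-fold higher number from compound 3 to compound 4 (0.38 log units; beyond the scatter). The arrangement of fluorine on the ring also counts here, since exchanging 2,6-difluorophenyl for 3,4-difluorophenyl gives a 5.8-fold lower number from compound 1 to compound 4 (0.76 log units; beyond the scatter). The other aryl position has its first single-place comparison, and a 1.2-fold higher number from compound 2 to compound 4 (0.09 log units; within the scatter) shows that this exchange of 2-(trifluoromethyl)phenyl for 3-(trifluoromethyl)phenyl is not resolved, though this rests on one pair. No measurement available here explains these steps.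

Still open, as far as these compounds go, is how the carbonyl position responds to an aryl ring carrying an amine or a carboxylic acid. A longer alkyl chain in place of the aryl ring at this position is equally untested in the compounds shown.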